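This account rests on a few compounds, and the source may have more. Where it says the series, first, only, none or still open, it means among the compounds named here.

Working notes on the series. In a functional assay on A549 cells (Homo sapiens) for antiproliferative activity, read by XTT assay, with a stated time of 72 h (a lower number here means a stronger inhibitor, a higher number a weaker inhibitor), compound 1 `COc1ccc(-c2cc3ccccc3nc2/C=C/C(=O)c2ccccc2)cc1` gives 7410 nM, the lowest of the three numbers in hand, but the other two stand within the scatter of it: compound 2 `COc1ccc(C(=O)/C=C/c2nc3ccccc3cc2-c2ccc(OC)cc2)cc1` gives 8500 nM and compound 3 `COc1ccc(-c2cc3ccccc3nc2/C=C/C(=O)c2ccc(N)cc2)cc1` gives 7530 nM. Both measured changes sit on the ring attached to the carbonyl carbon: a 1.1-fold higher number from compound 1 to compound 2 (0.06 log units; within the scatter), and a 1.0-fold higher number from compound 1 to compound 3 (0.01 log units; within the scatter). Between the two substituted compounds the reading is the same, a 1.1-fold lower number from compound 2 to compound 3 (0.05 log units; within the scatter). Compound 4 `COc1ccc(-c2cc3ccccc3nc2/C=C/C(=O)c2sccc2N)cc1` departs from compound 1 at that same ring, and by a larger change than either: 3-aminothiophen-2-yl in place of phenyl on a carbonyl carbon. Among the measured compounds shown here, no measured step exchanges the ring itself; the steps in hand only show that adding a methoxy or an amino to that ring leaves the number where it was. The amino is kept within the entering group, so compound 3 with 7530 nM is the closest reference. For compound 4 the number is therefore expected close to the parent, a 1.1-fold lower number from compound 1 to compound 4 (0.02 log units; within the scatter), estimated at 7000 nM with a range of 2500 nM to 20000 nM.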

Compound 4, half-maximal inhibitory concentration: > 10000 nM
Compound 4: no number, only a limit; the forecaster's own chance of this, stated with the estimate: 5%; at least 1.4-fold (0.15 log units) between middle value and limit.
By their numbers in this assay, from the lowest: compounds 1, 3 and 2 (each within the scatter of the next). At a limit, above all of these: compound 4.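

In this assay compound 4 stands at a limit of the assay and has no number: the limit of > 10000 nM in this assay, at which 1 of the 4 values shown sits. Against the other compounds this gives an at least 1.3-fold higher number from compound 1 to compound 4 (0.13 log units; that floor lies within the scatter), an at least 1.3-fold higher number from compound 3 to compound 4 (0.12 log units; that floor lies within the scatter) and an at least 1.1-fold higher number from compound 2 to compound 4 (0.07 log units; that floor lies within the scatter). Unlike the methoxy and amino steps on the phenyl ring, which are measured and small, this exchange of the ring itself on the carbonyl carbon has only a floor, so its full size is unknown and, with every floor inside the scatter, a real shift is not established.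

As far as these compounds go, how far compound 4 lies past the limit stays open, as does whether the five-membered ring or its amino governs the result. A plain thiophen-2-yl or a furan-2-yl on the carbonyl carbon would separate those two parts.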